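The source may hold more compounds than are shown below. What is called first, only, known or untested is meant among the compounds shown, and "the series" means these compounds.

Measured compounds:
compound 1 `O=S(=O)(NCCCNCc1ccc(Cl)cc1)c1cc(C(F)(F)F)cc(C(F)(F)F)c1` gives 2800 nM
compound 2 `CC(C)(C)c1ccc(CNCCCNS(=O)(=O)c2cc(C(F)(F)F)cc(C(F)(F)F)c2)cc1` gives 2000 nM
compound 3 `O=S(=O)(NCCCNCc1ccc(C(F)(F)F)cc1)c1cc(C(F)(F)F)cc(C(F)(F)F)c1` gives 2900 nM

In a functional assay on HT-29 cells (Homo sapiens) for inhibition, read by MTT assay, with a stated time of 72 h (on this read-out lower numbers stand for stronger inhibition of growth and higher numbers for weaker inhibition of growth), compound 3 stands at the highest of the three numbers, though its gaps to the others are within the scatter: a 1.0-fold higher number from compound 1 to compound 3 (0.02 log units; within the scatter) and a 1.5-fold higher number from compound 2 to compound 3 (0.16 log units; within the scatter). Compound 4 `O=S(=O)(NCCCNCc1ccccc1Cl)c1cc(C(F)(F)F)cc(C(F)(F)F)c1` carries the change (2-chlorophenyl in place of 4-(trifluoromethyl)phenyl on a saturated chain carbon bound to an amine nitrogen). For the measured compounds named here, the steps that bear on this are those that swap the group on that same ring, and both were small, as was a 1.4-fold lower number from compound 1 to compound 2 (0.15 log units; within the scatter). Going by the values given here, nothing among the measured compounds points to a shift beyond the scatter, so compound 4 is expected to give 2800 nM, within 1400 nM to 5600 nM, a step of a 1.0-fold lower number from compound 3 to compound 4 (0.02 log units; within the scatter) that is expected to stay within the scatter.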

Compound 4, concentration for 50% growth inhibition: 20000 nM
The estimate for compound 4 lay 7.1-fold (0.85 log units) below the measured number; measured number outside the range, above it.
By their numbers in this assay, from the lowest: compounds 2, 1 and 3 (each within the scatter of the next); then compound 4.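

In this assay, on a saturated chain carbon bound to an amine nitrogen, 4-chlorophenyl, 4-(tert-butyl)phenyl and 4-(trifluoromethyl)phenyl had stayed within the scatter of one another, but 2-chlorophenyl moves the number beyond it: a 7.1-fold higher number from compound 1 to compound 4 (0.85 log units; beyond the scatter), a 10-fold higher number from compound 2 to compound 4 (1.00 log units; beyond the scatter) and a 6.9-fold higher number from compound 3 to compound 4 (0.84 log units; beyond the scatter). The first of these steps only exchanges 4-chlorophenyl for 2-chlorophenyl, so at this place the site of the chlorine on the ring counts for more than the differences among the earlier groups. No measurement shown accounts for this weaker inhibition of growth. On these data alone, whether 2-fluorophenyl or 2-methylphenyl would also give a higher number remains open, as does whether 2-chlorobenzyl would behave the same way on a longer chain.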